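Replacing Fluoro with Trifluoromethyl: An Expected Small Step

A few compounds are considered here, and "the series" means these few. Any claim that something is new, unique, unknown or untested is made for them only; others in the source may bear on it.

- compound 1 `O=[N+]([O-])c1ccc(S(=O)(=O)n2c(-c3cn(-c4ccccc4)nc3-c3ccc(F)cc3)nc3ccccc32)cc1`: 1340 nM
- compound 2 `O=S(=O)(c1ccc(F)cc1)n1c(-c2cn(-c3ccccc3)nc2-c2ccc(F)cc2)nc2ccccc21`: 3520 nM

In a functional assay on HepG2 cells (Homo sapiens) for antiproliferative activity, read by MTT assay, with a stated time of 24 h (on this read-out lower numbers stand for stronger inhibition and higher numbers for weaker inhibition), compound 2 has the higher of the two numbers, at 3520 nM. Compound 3 `O=S(=O)(c1ccc(C(F)(F)F)cc1)n1c(-c2cn(-c3ccccc3)nc2-c2ccc(F)cc2)nc2ccccc21` has trifluoromethyl in place of fluoro on an aromatic carbon, para to a large group: trifluoromethyl in place of fluoro on an aromatic carbon. For the measured compounds named here, only one measured step involves that same carbon: a 2.6-fold higher number from compound 1 to compound 2 (0.42 log units; beyond the scatter). Going by the values given here, it is modest, and no measurement yet includes trifluoromethyl, so a modest step towards a lower number is expected, though none beyond the scatter remains possible. The expected change is a 1.7-fold lower number from compound 2 to compound 3 (0.22 log units; within the scatter). The estimate for compound 3 is 2100 nM, with an expected range of 900 nM to 4800 nM.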

Compound 3, half-maximal inhibitory concentration: 1680 nM
Beside the measured number, compound 3's estimate is 1.3-fold (0.10 log units) above it, within the range that was stated.
By their numbers in this assay, from the lowest: compounds 1 and 3 (each within the scatter of the next); then compound 2.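

In this assay, changing the group at this position gives a 2.1-fold lower number from compound 2 to compound 3 (0.32 log units; beyond the scatter), so a step beyond the scatter is now seen with a group other than nitro. Trifluoromethyl and nitro cannot be told apart here, as the comparison gives a 1.3-fold higher number from compound 1 to compound 3 (0.10 log units; within the scatter). So the two compounds with these groups read alike, and the fluoro compound 2 stands apart from both. No measurement shown bears on the cause of these steps. Still open, on these data alone, is how an amine or a carboxylic acid would read at this same position.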